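This account rests on a few compounds, and the source may have more. Where it says the series, first, only, none or still open, it means among the compounds named here.

Measured compounds:
compound 1 `C=CCc1c(OCC(O)COc2ccc3c(=O)cc(C(=O)O)oc3c2)ccc(C(C)=O)c1O` — 0.1 ug/mL
compound 2 `CCCc1c(OCC(O)COc2ccc3c(=O)cc(C(=O)O)oc3c2)ccc(C(C)=O)c1O` — 0.08 ug/mL
compound 3 `CCCc1ccccc1OCC(O)COc1ccc2c(=O)cc(C(=O)O)oc2c1` — 2 ug/mL

All three were run in a functional assay on ileum (Cavia porcellus) for antagonist activity, with a stated time of 30 s; on this read-out lower numbers stand for stronger inhibition and higher numbers for weaker inhibition. Within the data shown here, compound 2 and compound 1 share one core and differ only by vinyl in place of ethyl on a saturated chain carbon bound to an aromatic carbon; the step of a 1.3-fold higher number from compound 2 to compound 1 (0.10 log units; within the scatter) is the only measured instance of this change, and it leaves the read-out essentially where it was. Compound 3 carries a different core; the difference between the two cores is not broken down here, but in this assay compound 3 gives 2 ug/mL, well beyond the scatter from either compound 1 or compound 2.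

Compound 4 `C=CCc1ccccc1OCC(O)COc1ccc2c(=O)cc(C(=O)O)oc2c1` has not yet been measured. It differs from compound 3 by vinyl in place of ethyl on a saturated chain carbon bound to an aromatic carbon, the same change as from compound 2 to compound 1, at the same kind of position. Because the earlier step of a 1.3-fold higher number from compound 2 to compound 1 (0.10 log units; within the scatter) stayed within the scatter, the expectation for compound 4 is a step of about a 1.3-fold higher number from compound 3 to compound 4 (0.10 log units; within the scatter), with no clear direction. On that basis compound 4 is estimated at 2.5 ug/mL in this assay, with a range of 1 ug/mL to 6 ug/mL.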

Compound 4, half-maximal inhibitory concentration: 1.8 ug/mL
Compound 4: middle estimate off by 1.4-fold (0.14 log units), on the high side; the range from low to high includes it.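

In this assay the swap of propyl for allyl gives a 1.1-fold lower number from compound 3 to compound 4 (0.05 log units; within the scatter) and so leaves the read-out essentially where it was on the core of compound 3. Set beside the earlier step, the change carries from one core to the other with no measurable difference between the two steps: the same change on two cores in this assay, a 1.3-fold higher number (0.10 log units; within the scatter) from compound 2 to compound 1 and a 1.1-fold lower number (0.05 log units; within the scatter) from compound 3 to compound 4, 1.4-fold (0.14 log units) apart, within the scatter of two such steps.

This does not show that the change would behave the same way on any other core or in any other assay, since the comparison rests on two pairs in one assay, and with both steps within the scatter it gives the change no direction.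

The compounds shown leave open what a longer chain such as butyl, or a chain ending in an amine or a carboxylic acid, would do on a saturated chain carbon bound to an aromatic carbon. They also leave open which part of the difference between the two cores goes with the gap in the read-out.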